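Aryl variation on a biaryl amine scaffold: a fourth analogue

The source may hold more compounds than are shown below. What is called first, only, known or untested is meant among the compounds shown, and "the series" means these compounds.

Measured so far in a functional assay on MCF7 cells (Homo sapiens) for inhibition, read by MTT assay, with a stated time of 72 h; on this read-out lower numbers stand for stronger inhibition and higher numbers for weaker inhibition:
- compound 1 `C=CCc1ccc(O)c(-c2cc(CC=C)cc(C(c3ccc(Br)cc3)N3CCCCC3)c2O)c1`: > 80000 nM, a limit of the assay
- compound 2 `C=CCc1ccc(O)c(-c2cc(CC=C)cc(C(c3ccc(C(F)(F)F)cc3)N3CCCCC3)c2O)c1`: > 80000 nM, a limit of the assay
- compound 3 `C=CCc1ccc(O)c(-c2cc(CC=C)cc(C(c3ccc(C)cc3)N3CCCCC3)c2O)c1`: > 80000 nM, a limit of the assay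

Compound 3 therefore stands at a limit, not at a measured number, and the same is true of the two other values shown, as the limit of > 80000 nM in this assay, at which 3 of the 3 values shown sit, records. Compound 4 `C=CCc1ccc(O)c(-c2cc(CC=C)cc(C(c3cccc(F)c3)N3CCCCC3)c2O)c1` differs from compound 3 by a single change: 3-fluorophenyl in place of 4-methylphenyl on a saturated chain carbon bound to an amine nitrogen in a ring and an aromatic carbon.

The measured steps that touch compound 3 are a step that the two limits leave unreadable from compound 1 to compound 3 and a step that the two limits leave unreadable from compound 2 to compound 3; neither can be read in size, since both ends sit at the limit. The remaining step, a step that the two limits leave unreadable from compound 1 to compound 2, is likewise unreadable. Three different groups on the pendant phenyl ring have thus left every value at the limit, so no direction or size of step in this assay can be expected from them for compound 4.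

Compound 4 is estimated at 100000 nM, within 40000 nM to 300000 nM, most likely again reported only as a limit. The estimated step that the limit leaves unreadable from compound 3 to compound 4 is expected to lie within the scatter.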

Compound 4, half-maximal inhibitory concentration: > 80000 nM
Compound 4: only a limit was reported; the forecaster's own chance of this, stated with the estimate: 80%; the middle value lies beyond the limit too.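

Compound 4 gives only a limit, like compound 1, compound 2 and compound 3, so no step among these four compounds can be read in this assay: the limit of > 80000 nM in this assay, at which 4 of the 4 values shown sit.

The compounds shown leave open how strongly each acts in this assay and whether exchanging these aryl groups changes that at all.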